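A Carboxy Swap on a Compound at the Limit

The source may hold more compounds than are shown below. What is called first, only, known or untested is meant among the compounds shown, and "the series" means these compounds.

Of the compounds shown here, three have been read so far in an ADME assay on HaCaT cells (Homo sapiens) for antiproliferative activity, with a stated time of 48 h (on this read-out higher numbers stand for weaker inhibition and lower numbers for stronger inhibition), and none has given a number. Compound 1 (`COc1ccc(Nc2ccc(-c3ccccc3)nn2)cc1`) reads > 25000 nM in this test, which is a limit. Compound 2 (`CCN(CC)c1ccc(-c2cccc(Cl)c2)nn1`) reads > 25000 nM here, again a limit. Compound 3 (`CCN(CC)c1ccc(-c2ccc(C#N)cc2)nn1`) reads > 25000 nM as well, and this too is a limit rather than a number. Compound 3 thus stands with the other two, and the whole set sits at the limit of > 25000 nM in this assay, at which 3 of the 3 values shown sit, with no exception.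

Compound 4 (`CCN(CC)c1ccc(-c2ccc(C(=O)O)cc2)nn1`) has not yet been measured. It carries carboxy in place of cyano on an aromatic carbon, para to a large group: carboxy in place of cyano on an aromatic carbon. Within the data shown here, no step between measured compounds that differ in one place is available to guide the size of this change. The expectation therefore rests on the limit of > 25000 nM in this assay, at which 3 of the 3 values shown sit, alone, and no step beyond the scatter is expected in this assay in either direction. The expected change is a number no higher from compound 3 to compound 4 (the limit leaves the size open) and it is only an estimate. Compound 4 is estimated at 25000 nM, with an expected range from 15000 nM to 40000 nM, and it will most likely read as a limit once more.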

Compound 4, half-maximal inhibitory concentration: > 25000 nM
Compound 4 was reported as a limit (the forecaster's own chance of this, stated with the estimate: 90%); the middle value lies on the limit itself.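

In this assay compound 4 gives > 25000 nM as a limit and not a number. Compound 3 also reads as a limit, so no step can be read between compound 3 and compound 4. The compounds shown leave open whether any of them has a measurable potency, and so how carboxy in place of cyano changes it: the limit of > 25000 nM in this assay, at which 4 of the 4 values shown sit.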